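The source may hold more compounds than are shown below. What is called first, only, known or untested is meant among the compounds shown, and "the series" means these compounds.

Working notes on the bromophenyl acrylamide series.

Three compounds have been run in a toxicity assay on the whole organism (strain Icem-CET (SPF Caw)) for cytotoxicity, with Mus musculus as the target; on this read-out lower numbers stand for an effect already at smaller amounts and higher numbers for an effect only at larger amounts of compound. Compound 1 `C/C(C(=O)NC1CC1)=C(\C)c1ccc(Br)cc1` gives 300 mg/kg in this assay. Compound 2 `C=CCNC(=O)/C(C)=C(\C)c1ccc(Br)cc1` gives 120 mg/kg. Compound 3 `C/C(C(=O)NC1CC1)=C(/C)c1ccc(Br)cc1` gives 100 mg/kg, the lowest number of the three. The step of a 1.2-fold lower number from compound 2 to compound 3 (0.08 log units; within the scatter) stays within the scatter, so compound 2 and compound 3 are not told apart. The step of a 3.0-fold lower number from compound 1 to compound 3 (0.48 log units; beyond the scatter) lies beyond the scatter, and these two compounds differ only in configuration as drawn (the fact that compounds 1 and 3 differ only in the configuration as drawn).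

Compound 4 `C/C(C(=O)NC1CC1)=C(/C)c1ccc(Cl)cc1` is the next member: chloro in place of bromo on an aromatic carbon. Neither measured step bears on this change: one concerned the geometry of the double bond, the other the group on the amide nitrogen. Going by the values given here, no measured step touches the halogen on the aromatic ring, so there is no basis for a directed shift. The step of no change at the digits printed from compound 3 to compound 4 (within the scatter) is therefore expected to stay within the scatter. Compound 4 is expected to give about 100 mg/kg, in the range 50 mg/kg to 200 mg/kg.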

Compound 4, dose for half-maximal effect: 350 mg/kg
Beside the measured number, compound 4's estimate is 3.5-fold (0.54 log units) below it; measured number above the stated range.
By their numbers in this assay, from the lowest: compounds 3 and 2 (each within the scatter of the next); then compounds 1 and 4 (each within the scatter of the next).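

In this assay, chloro in place of bromo on an aromatic carbon, para to a large group, gives a 3.5-fold higher number from compound 3 to compound 4 (0.54 log units; beyond the scatter). Compounds 1, 2 and 3 all carry bromo, so they could not show that the halogen at this position moves the number at all; this step shows that it does, with the bromo compound at the lower number and the chloro compound at the higher one. Nothing at hand bears on why this exchange shifts the number.

The compounds shown leave open how other groups at this position, such as fluoro, iodo or methoxy, would read in this assay. They also leave open whether the halogen step holds with the double bond in the other geometry or with allyl on the amide nitrogen.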